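From 2-fluorophenyl to 4-methylphenyl on the shared core

The source may hold more compounds than are shown below. What is called first, only, known or untested is meant among the compounds shown, and "the series" means these compounds.

In a functional assay on PC-3 cells (Homo sapiens) for cytotoxicity, read by sulforhodamine B assay, with a stated time of 48 h (a higher number here means a weaker inhibitor, a lower number a stronger inhibitor), compound 1 `C[C@H]1CC[C@@H]2[C@@H](OC(=O)[C@]23CC(c2c(Cl)cccc2Cl)=NO3)[C@]2(C)C(=O)C=C[C@@]12O` gives 56000 nM and compound 2 `C[C@H]1CC[C@@H]2[C@@H](OC(=O)[C@]23CC(c2ccccc2F)=NO3)[C@]2(C)C(=O)C=C[C@@]12O` gives 8200 nM. Among the compounds with values here, compound 2 therefore holds the lower of only two numbers, which makes it the stronger inhibitor of the pair. Compound 3 `Cc1ccc(C2=NO[C@]3(C2)C(=O)O[C@@H]2[C@H]3CC[C@H](C)[C@]3(O)C=CC(=O)[C@@]23C)cc1` keeps the same core but carries 4-methylphenyl in place of 2-fluorophenyl on a carbon with a double bond to nitrogen.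

Within the data shown here, only one measured step bears on this change. It is a 6.8-fold lower number from compound 1 to compound 2 (0.83 log units; beyond the scatter), which came with 2-fluorophenyl in place of 2,6-dichlorophenyl at the same place. That step shows that the group at this place can move the number in this assay, but neither measured compound carries 4-methylphenyl, so the data give no firm direction. Compound 2 sits at the low end of a very small set, so a slight rise is expected rather than a further fall. The expected change is a 1.7-fold higher number from compound 2 to compound 3 (0.23 log units; within the scatter), smaller than the measured step. For compound 3 the estimated value is 14000 nM, with an expected range from 4000 nM to 45000 nM.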

Compound 3, half-maximal inhibitory concentration: 14000 nM
The estimate for compound 3 equals the measured number at the digits printed, and the stated range covers the measured number.
By their numbers in this assay, from the lowest: compounds 2 and 3 (each within the scatter of the next); then compound 1.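

In this assay, 4-methylphenyl in place of 2-fluorophenyl gives a 1.7-fold higher number from compound 2 to compound 3 (0.23 log units; within the scatter) on the shared core, so at this place these two groups, each with 7 heavy atoms and one six-membered aromatic ring of carbon only, cannot be told apart. 4-Methylphenyl in place of 2,6-dichlorophenyl gives a 4.0-fold lower number from compound 1 to compound 3 (0.60 log units; beyond the scatter) in the same assay, so compound 1 now stands apart from two different groups rather than one, and a fluorine on the ring is not needed to clear compound 1, since compound 3 carries none. No measurement of any other kind is available here to account for these numbers.

From the compounds shown here alone, all three compounds carry a substituted phenyl on this carbon with a double bond to nitrogen, so it remains open how a plain phenyl, or a phenyl bearing an amine or a carboxylic acid, would read in this assay. Going by these compounds, it is also open whether a longer chain in place of the methyl of compound 3 would stay with compounds 2 and 3 or move the number beyond the scatter in either direction.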